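Isopropylsulfanyl step at the cytotoxicity limit

This account rests on a few compounds, and the source may have more. Where it says the series, first, only, none or still open, it means among the compounds named here.

In an ADME assay on BCBL1 cells (Homo sapiens) for cytotoxicity, with a stated time of 7 days (on this read-out lower numbers stand for higher toxicity in this test and higher numbers for lower toxicity in this test), compound 3 (`CSc1nc(N)nc2c1ncn2/C=C1/CC1(CO)CO`) gives > 20000 nM as a limit and not a number. Compound 2 (`CCCSc1nc(N)nc2c1ncn2/C=C1/CC1(CO)CO`) gives > 20000 nM and this too is a limit. Compound 1 (`Nc1nc(OCc2ccccc2)c2ncn(/C=C3/CC3(CO)CO)c2n1`) gives > 20000 nM and this is likewise a limit. Compound 3 therefore has no measured number and stands with the other two at the limit of > 20000 nM in this assay, at which 3 of the 3 values shown sit, in this series.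

Compound 4 (`CC(C)Sc1nc(N)nc2c1ncn2/C=C1/CC1(CO)CO`) has isopropyl in place of methyl on a sulfur and is otherwise the same as compound 3. The closest measured change is a step that the two limits leave unreadable from compound 2 to compound 3 as it also alters the group on a sulfur. The other two measured changes, a step that the two limits leave unreadable from compound 1 to compound 2 and a step that the two limits leave unreadable from compound 1 to compound 3, also give no size.

No step beyond the scatter and no direction can be expected in this assay on this evidence. The expected outcome is a step that the limit leaves unreadable from compound 3 to compound 4 as an estimate only. For compound 4 the estimated value is 25000 nM with an expected range of 12000 nM to 50000 nM and a report of only a limit is likely.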

Compound 4, half-maximal cytotoxic concentration: > 20000 nM
Compound 4 ended at the assay's limit; the forecaster's own chance of this, stated with the estimate: 88%; the middle value is on the limit's open side.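

In this assay compound 4 gives > 20000 nM, a limit and not a number, so no step from it to compound 1, compound 2 or compound 3 can be read: the limit of > 20000 nM in this assay, at which 4 of the 4 values shown sit.

The compounds shown leave open how these four rank and at what concentration any of them becomes cytotoxic.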